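This account rests on a few compounds, and the source may have more. Where it says the series, first, only, none or still open, it means among the compounds named here.

Compound 1 `CCN(Cc1c(C(F)(F)F)nc2n(-c3c(C)cc(C)cc3C)c(Cl)cn12)CC1CCC1`: 16 nM
Compound 2 `CCN(CCC1CC1)Cc1c(C(F)(F)F)nc2n(-c3c(C)cc(C)cc3C)c(Cl)cn12`: 13 nM
Compound 3 `CCN(Cc1ccccc1)Cc1c(C(F)(F)F)nc2n(-c3c(C)cc(C)cc3C)c(Cl)cn12`: 350 nM

All three compounds share one core and differ only in the group carried on a saturated chain carbon bound to an amine nitrogen. In an assay on cells for displacement of a labelled ligand from corticotropin-releasing factor receptor 1 (Homo sapiens), with a stated time of 100 min (on this read-out lower numbers stand for stronger inhibition and higher numbers for weaker inhibition), compound 3 gives 350 nM, the highest number of the three. Its cyclobutyl and cyclopropylmethyl neighbours sit close together (a 1.2-fold lower number from compound 1 to compound 2 (0.09 log units; within the scatter)), while the phenyl of compound 3 costs a great deal: a 22-fold higher number from compound 1 to compound 3 (1.34 log units; beyond the scatter) and a 27-fold higher number from compound 2 to compound 3 (1.43 log units; beyond the scatter).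

Compound 4 `CCN(Cc1ccc(Cl)c(Cl)c1)Cc1c(C(F)(F)F)nc2n(-c3c(C)cc(C)cc3C)c(Cl)cn12` keeps the phenyl but decorates it: 3,4-dichlorophenyl in place of phenyl on a saturated chain carbon bound to an amine nitrogen. Within the data shown here, no measured step involves adding chlorine to this ring; the two large steps above concern exchanging the whole group, not changing it. Among the measured compounds shown here, the nearest evidence is therefore only that a benzyl-type group is tolerated at this position but weakly. With nothing pointing either way, the expected step in this assay is small, a 1.4-fold lower number from compound 3 to compound 4 (0.15 log units; within the scatter), and compound 4 is estimated at 250 nM, somewhere between 70 nM and 900 nM.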

Compound 4, inhibition constant: 580 nM
Compound 4: the middle estimate sits 2.3-fold (0.37 log units) below what was measured; low and high end bracket the measured number.
By their numbers in this assay, from the lowest: compounds 2 and 1 (each within the scatter of the next); then compounds 3 and 4 (each within the scatter of the next).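

In this assay, 3,4-dichlorophenyl in place of phenyl on a saturated chain carbon bound to an amine nitrogen gives a step within the scatter (a 1.7-fold higher number from compound 3 to compound 4 (0.22 log units; within the scatter)), so these two aromatic groups cannot be told apart here. The large gap to the saturated groups therefore holds for the dichlorinated ring as well, both against cyclopropylmethyl (a 45-fold higher number from compound 2 to compound 4 (1.65 log units; beyond the scatter)) and against cyclobutyl (a 36-fold higher number from compound 1 to compound 4 (1.56 log units; beyond the scatter)). Nothing measured here says what lies behind these numbers.

The compounds shown leave open whether a ring carrying something other than chlorine, such as a methoxy group or a nitrile, would stand apart from phenyl, and whether a single chlorine would match the pair. They also leave open how cyclohexyl or a longer chain would compare with the cyclobutyl and cyclopropylmethyl groups.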